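The compounds below may be only part of what the source reports. "The series", "measured", "known", "first", "only" and "open" are said of these compounds alone.

Measured in a functional assay on colon cells (Homo sapiens) for antiproliferative activity; a higher number here means a weaker inhibitor of growth, a lower number a stronger inhibitor of growth:
compound 1 `Cc1cn2c(/C=N/NC(=N)N)c(-c3cccnc3)nc2s1`: 5620 nM
compound 2 `N=C(N)N/N=C/c1c(-c2ccccn2)nc2sc(Cl)cn12`: 7080 nM

With only these two values to go on, compound 2 stands level with compound 1, as the gap between them lies within the usual scatter. Compound 3 `N=C(N)N/N=C/c1c(-c2cccnc2)nc2sc(Cl)cn12` differs from compound 2 in one place: pyridin-3-yl in place of pyridin-2-yl on an aromatic carbon. For the measured compounds named here, no measured pair shows this swap alone, but compound 1 also bears pyridin-3-yl, though it differs elsewhere too, and gives 5620 nM. No step beyond the scatter is therefore expected in this assay. The estimated change is a 1.2-fold lower number from compound 2 to compound 3 (0.09 log units; within the scatter). For compound 3 the expected value is 5800 nM, within an estimated range of 2300 nM to 14000 nM.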

Compound 3, concentration for 50% growth inhibition: 8510 nM
Beside the measured number, compound 3's estimate is 1.5-fold (0.17 log units) below it, within the range that was stated.
By their numbers in this assay, from the lowest: compounds 1, 2 and 3 (each within the scatter of the next).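

In this assay, pyridin-3-yl in place of pyridin-2-yl gives a step that stays within the scatter (a 1.2-fold higher number from compound 2 to compound 3 (0.08 log units; within the scatter)), so this position does not separate these two attachments of the pyridine ring. With pyridin-3-yl held fixed, chloro in place of methyl also stays within the scatter (a 1.5-fold higher number from compound 1 to compound 3 (0.18 log units; within the scatter)), so these two groups cannot be told apart either. Nothing measured here offers an explanation for these results.

Still open, from the compounds shown here alone, is whether a plain phenyl ring or a carboxylic acid at this position would produce a real step. The same question applies to a hydrogen or a longer chain in place of chloro.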